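Isopropoxy in Place of Benzylamino on a Shared Core

This account rests on a few compounds, and the source may have more. Where it says the series, first, only, none or still open, it means among the compounds named here.

compound 1 `COc1ccc(-c2cnc3nc(N)nc(NC(C)C)c3n2)cc1OC` — 600 nM
compound 2 `COc1ccc(-c2cnc3nc(N)nc(NCc4ccccc4)c3n2)cc1OC` — 13000 nM

In a functional assay on cells (T-cell, Homo sapiens) for inhibition (a lower number here means a stronger inhibitor, a higher number a weaker inhibitor), compound 1 gives 600 nM, while compound 2 gives 13000 nM, the highest of the two numbers, with compound 1 the nearest. Compound 3 `COc1ccc(-c2cnc3nc(N)nc(OC(C)C)c3n2)cc1OC` differs from compound 2 by isopropoxy in place of benzylamino on an aromatic carbon. Among the compounds with values here, the one measured step that bears on this is a 22-fold higher number from compound 1 to compound 2 (1.34 log units; beyond the scatter), a large rise. Because a 22-fold higher number from compound 1 to compound 2 (1.34 log units; beyond the scatter) is a large rise and the entering group returns to the isopropyl of compound 1 while the hydrogen-bond donor is lost, a large step downward is expected, an 8.7-fold lower number from compound 2 to compound 3 (0.94 log units; beyond the scatter). Compound 3 is therefore estimated at 1500 nM, in the range 400 nM to 6000 nM.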

Compound 3, half-maximal inhibitory concentration: 400 nM
Estimate against measurement, compound 3: 3.8-fold (0.57 log units) above; measured number inside the range.
By their numbers in this assay, from the lowest: compounds 3 and 1 (each within the scatter of the next); then compound 2.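

Isopropoxy in place of benzylamino gives a 33-fold lower number from compound 2 to compound 3 (1.51 log units; beyond the scatter) in this assay while isopropoxy in place of isopropylamino gives a 1.5-fold lower number from compound 1 to compound 3 (0.18 log units; within the scatter) so the oxygen and nitrogen links cannot be told apart when they carry isopropyl. The hydrogen-bond donor of compound 1 is therefore not needed to keep this level at this position, and the large difference tracks benzyl against isopropyl. No evidence given here explains these results. On these data alone, whether benzyloxy would match benzylamino remains open. So does whether methoxy or cyclopentyloxy would hold the level of isopropoxy.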